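A few compounds are considered here, and "the series" means these few. Any claim that something is new, unique, unknown or untested is made for them only; others in the source may bear on it.

In an ADME assay on MT4 cells (Homo sapiens) for cytotoxicity, read by MTT assay, with a stated time of 5 days (on this read-out lower numbers stand for higher toxicity in this test and higher numbers for lower toxicity in this test), compound 1 `Cc1cc(C#N)cc(C)c1Oc1nc(NC2CCC(NC(=O)c3ccccc3)CC2)nc2ccsc12` gives 3930 nM, compound 2 `Cc1cc(C#N)cc(C)c1Oc1nc(NC2CCC(NC(=O)c3ccc(F)cc3)CC2)nc2ccsc12` gives 3180 nM, and compound 3 `Cc1cc(C#N)cc(C)c1Oc1nc(NC2CCC(NC(=O)c3ccc(Br)cc3)CC2)nc2ccsc12` gives 2850 nM. The three differ only in the group on the benzamide ring, and none of the steps between them rises above the scatter: a 1.2-fold lower number from compound 1 to compound 2 (0.09 log units; within the scatter), a 1.4-fold lower number from compound 1 to compound 3 (0.14 log units; within the scatter) and a 1.1-fold lower number from compound 2 to compound 3 (0.05 log units; within the scatter). Compound 3 therefore sits at the low end of the three numbers in this assay, but with compound 2 and compound 1 both within the scatter of it, so no order can be read from these figures.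

Compound 4 `Cc1cc(C#N)cc(C)c1Oc1nc(NC2CCC(NC(=O)c3ccc(C#N)cc3)CC2)nc2ccsc12` continues the same series: cyano in place of bromo on an aromatic carbon. Within the data shown here, the steps that bear on this change are the two that put fluoro and bromo at this position, a 1.2-fold lower number from compound 1 to compound 2 (0.09 log units; within the scatter) and a 1.4-fold lower number from compound 1 to compound 3 (0.14 log units; within the scatter), and the swap between them, a 1.1-fold lower number from compound 2 to compound 3 (0.05 log units; within the scatter); all three are small. On that basis compound 4 is expected to show no step beyond the scatter in this assay, the expected step being a 1.1-fold higher number from compound 3 to compound 4 (0.02 log units; within the scatter). The estimate for compound 4 in this assay is 3000 nM, with a range from 1500 nM to 6000 nM.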

Compound 4, half-maximal cytotoxic concentration: 2620 nM
Compound 4: the middle estimate sits 1.1-fold (0.06 log units) above what was measured; the measured number falls inside the stated range.
By their numbers in this assay, from the lowest: compounds 4, 3, 2 and 1 (each within the scatter of the next).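

In this assay the change from 4-bromophenyl to 4-cyanophenyl brings in a triple bond and a hydrogen-bond acceptor, neither of which bromo has, yet the result is only a 1.1-fold lower number from compound 3 to compound 4 (0.04 log units; within the scatter). The earlier compounds shown here had tested only hydrogen, fluoro and bromo at this place, para to a large group, and the new group leaves the picture unchanged: the comparison with fluoro gives a 1.2-fold lower number from compound 2 to compound 4 (0.08 log units; within the scatter), and the comparison with hydrogen gives a 1.5-fold lower number from compound 1 to compound 4 (0.18 log units; within the scatter), which is the widest of the three new steps and still does not clear the scatter. All four benzamides therefore remain indistinguishable on this read-out, and no measurement shown here accounts for that.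

The compounds shown leave open whether a group of a different kind at this place, such as an amine, a carboxylic acid or a longer alkyl chain, would move the number beyond the scatter. They also leave open whether changes elsewhere in the molecule, in the amide link or the shared core, would matter more than this substituent does.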